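From Methoxymethyl to Propylamino on the Carbonyl

A few compounds are considered here, and "the series" means these few. Any claim that something is new, unique, unknown or untested is made for them only; others in the source may bear on it.

Compound 1 `CN1CCN(S(=O)(=O)c2ccc(NC(=O)c3ccccc3)c3ccccc23)CC1` gives > 30000 nM
Compound 2 `CCOC(=O)N1CCC(NS(=O)(=O)c2ccc(C(=O)Nc3ccccc3C)c3ccccc23)CC1` gives 5.21 nM
Compound 3 `COCC(=O)N1CCC(NS(=O)(=O)c2ccc(NC(=O)c3ccccc3C)c3ccccc23)CC1` gives 15.8 nM

These three compounds share a core and were tested in an assay on L1.2 cells for binding affinity to C-C chemokine receptor type 8 (Homo sapiens); a lower number here means a stronger inhibitor, a higher number a weaker inhibitor. For compound 1 the reading is a limit of the assay rather than a number; compound 1 sits at the limit of > 30000 nM in this assay, at which 1 of the 3 values shown sits. Among the two actual numbers, compound 3 has the higher one, and compound 2 the lower, with the gap between them beyond the usual scatter of repeated measurements.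

Compound 4 `CCCNC(=O)N1CCC(NS(=O)(=O)c2ccc(NC(=O)c3ccccc3C)c3ccccc23)CC1` has not yet been measured. It differs from compound 3 in one place: propylamino in place of methoxymethyl on a carbonyl carbon. In compound 3 a methoxymethyl group sits on that carbonyl; in compound 4 a propylamino group takes its place, turning the amide into a urea.

Going by the values given here, no measured pair in this set makes the same change, so the size of the step cannot be read from a neighbour. The expectation for compound 4 is therefore anchored on compound 3, with a step of a 1.3-fold lower number from compound 3 to compound 4 (0.12 log units; within the scatter) that is expected to stay within, or only just beyond, the scatter, in no firm direction. Compound 4 is estimated at 12 nM in this assay, expected between 4 nM and 40 nM.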

Compound 4, inhibition constant: 77.4 nM
The estimate for compound 4 lay 6.5-fold (0.81 log units) below the measured number, outside the stated range (above it).
By their numbers in this assay, from the lowest: compound 2; then compound 3; then compound 4. At a limit, above all of these: compound 1.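

On the carbonyl carbon that also carries the ring amide-type nitrogen, replacing methoxymethyl with propylamino in this assay gives a 4.9-fold higher number from compound 3 to compound 4 (0.69 log units; beyond the scatter), so the group at this place does affect the reading, and the two groups are not interchangeable. This swap turns the amide into a urea, exchanging a group with a hydrogen-bond acceptor for one with a hydrogen-bond donor, and compound 4 gives 77.4 nM. Nothing measured in this set bears on why the number rises, so the step stands as an observation only.

Because one swap changes the chain and the atom attached to the carbonyl together, the compounds shown leave open whether the rise follows the nitrogen with its hydrogen, the oxygen that leaves, or the chain itself. A plain butyl chain on the carbonyl, a dimethylamino group with no hydrogen on its nitrogen, or a shorter ethylamino group would help to pull these apart.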